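Further branching at the carbon bound to double-bonded nitrogen

The source may report more compounds than this note shows. Statements on the series, on what has been measured and on what is new or still open speak of the compounds shown alone.

Two compounds of the series have been run in a functional assay on the whole organism (blood, strain Wistar-Okamoto) with Rattus norvegicus as the target, with a stated time of 5 days; on this read-out lower numbers stand for an effect already at smaller amounts and higher numbers for an effect only at larger amounts of compound. Compound 1 `CCC(C)/N=C(\NC#N)Nc1cccnc1` gives 20 mg/kg. Compound 2 `CCCC(C)(C)/N=C(\NC#N)Nc1cccnc1` gives 1 mg/kg. Among these two numbers compound 2 stands lowest, and the step of a 20-fold lower number from compound 1 to compound 2 (1.30 log units; beyond the scatter) that separates it from compound 1 is large.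

Compound 3 `CC(C)(C)C(C)(C)/N=C(\NC#N)Nc1cccnc1` is the next member and differs from compound 2 in one place: tert-butyl in place of propyl on a saturated chain carbon bound to a double-bonded nitrogen and two saturated chain carbons. Going by the values given here, the only measured step that bears on this change is a 20-fold lower number from compound 1 to compound 2 (1.30 log units; beyond the scatter), where a larger branched group at the same place brought a large lowering. A single step does not show whether a second enlargement keeps lowering the number or whether the gain has already been taken; the expectation is a modest further lowering, possibly none beyond the scatter, rather than a repeat of the first step. For compound 3 the estimated step is a 1.4-fold lower number from compound 2 to compound 3 (0.15 log units; within the scatter). Compound 3 is therefore expected to give 0.7 mg/kg in this assay, with a range from 0.2 mg/kg to 2.5 mg/kg.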

Compound 3, minimum effective dose: 50 mg/kg
Beside the measured number, compound 3's estimate is 71-fold (1.85 log units) below it, and the stated range ends below it.
By their numbers in this assay, from the lowest: compound 2; then compound 1; then compound 3.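

In this assay, the saturated chain carbon bound to a double-bonded nitrogen and two saturated chain carbons does not tolerate unlimited enlargement: tert-butyl in place of propyl gives a 50-fold higher number from compound 2 to compound 3 (1.70 log units; beyond the scatter) and so more than cancels the earlier gain of a 20-fold lower number from compound 1 to compound 2 (1.30 log units; beyond the scatter) in this series. Across these three compounds the numbers do not follow group size in one direction, since compound 2 has the lowest number, while compound 1 gives 20 mg/kg and compound 3 gives 50 mg/kg. The exchange of propyl, with 3 heavy atoms, for tert-butyl, with 4 heavy atoms, is enough for this large step, and no supporting measurement is available to explain it.

Open, from the compounds shown here alone, is whether the sharp rise follows from the added carbon or from its branched arrangement, which ethyl, butyl or isobutyl in place of propyl would help to separate. Also open, going by these compounds, is how a ring such as cyclopropyl or cyclohexyl, or a polar group such as a hydroxyl or an amine on the propyl chain, would read out at this position.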